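A few compounds are considered here, and "the series" means these few. Any claim that something is new, unique, unknown or untested is made for them only; others in the source may bear on it.

Going by the values given here, in a physicochemical assay for lipophilicity, using the shake flask method, measured as octanol-water partition, at pH 7.4 (a lower number here means a more polar compound, a higher number a more lipophilic compound), compound 2 `CCn1cc(-c2ccnc3[nH]c(C4CCN(CC(=O)N(C)C)CC4)cc23)ccc1=O` gives 1.2, the lower of the two numbers so far, while compound 1 `CC(C)n1cc(-c2ccnc3[nH]c(C4CCN(CC(=O)N(C)C)CC4)cc23)ccc1=O` gives 1.9. Compound 3 `CN(C)C(=O)CN1CCC(c2cc3c(-c4ccc(=O)n(C5CCC5)c4)ccnc3[nH]2)CC1` has cyclobutyl in place of ethyl on an aromatic nitrogen. Among the compounds with values here, one measured step bears on this change, a number 0.70 log units lower from compound 1 to compound 2 (beyond the scatter), where hydrogen replaces methyl on the saturated chain carbon bound to that aromatic nitrogen. Read in reverse, that modest step suggests a rise of similar or slightly larger size as carbon is added here. The expected change is a number 0.90 log units higher from compound 2 to compound 3 (beyond the scatter). For compound 3 the estimated value is 2.1, with an expected range from 1.7 to 2.5.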

Compound 3, distribution coefficient: 1.9
For compound 3 the middle estimate is 0.20 log units above the measured one; measured number inside the range.
By their numbers in this assay, from the lowest: compound 2; then compounds 1 and 3 (each within the scatter of the next).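

In this assay, cyclobutyl in place of ethyl on this aromatic nitrogen gives a number 0.70 log units higher from compound 2 to compound 3 (beyond the scatter), so a ring here moves the number as the branched isopropyl of compound 1 does. Cyclobutyl in place of isopropyl gives no change at the digits printed from compound 1 to compound 3 (within the scatter), so this assay does not separate the two groups at this position. Nothing measured here explains why. The compounds shown leave open how a cyclopentyl or a hydroxyethyl group on this nitrogen would read in this assay.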